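The compounds below may be only part of what the source reports. "The series", "measured", "known", "first", "only" and "open" are said of these compounds alone.

Compound 1 `COc1ccc2oc(=O)c(C(=O)Nc3ccccc3)cc2c1` is the reference point of this small set, and it was examined in an assay on cells for inhibition of Amine oxidase [flavin-containing] B (Homo sapiens), read by fluorescence and Amplex Red, using microsomes, with a stated time of 15 min (a lower number here means a stronger inhibitor, a higher number a weaker inhibitor), where compound 1 gives 5.95 nM. Compound 2 `COc1ccc2occ(C(=O)Nc3ccccc3)c(=O)c2c1` is built on a different core; the difference between the two cores is not broken down here, although the two share the same atoms joined differently. In this assay compound 2 gives 41.8 nM, and compound 1 therefore stands lowest of the three measured numbers, with compound 2 the furthest from it. Compound 3 `COc1ccc2occ(C(=O)Nc3cccc(C)c3)c(=O)c2c1` carries one change relative to compound 2, namely methyl in place of hydrogen on an aromatic carbon In this assay compound 3 gives 21.8 nM, so that the step is a 1.9-fold lower number from compound 2 to compound 3 (0.28 log units; within the scatter).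

Compound 4 `COc1ccc2oc(=O)c(C(=O)Nc3ccc(C)cc3)cc2c1` is the compound whose number is not yet known. Within the data shown here, its difference from compound 1 is methyl in place of hydrogen on an aromatic carbon This is the same kind of change as the one from compound 2 to compound 3, but not the same: in compound 3 the methyl sits meta to a large group, whereas in compound 4 it sits para to a large group. The expectation for compound 4 rests on compound 1 and its value 5.95 nM, together with the small step seen as a 1.9-fold lower number from compound 2 to compound 3 (0.28 log units; within the scatter). In this assay the step from compound 1 to compound 4 is estimated to be a 1.3-fold lower number from compound 1 to compound 4 (0.12 log units; within the scatter). Compound 4 is accordingly expected to give about 4.5 nM, with a likely range from 2 nM to 10 nM.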

Compound 4, half-maximal inhibitory concentration: 19.4 nM
Compound 4: middle estimate off by 4.3-fold (0.63 log units), on the low side, outside the stated range (above it).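

In this assay the methyl change does not carry over from one core to the other as a single step. On the core of compound 1 it gives a 3.3-fold higher number from compound 1 to compound 4 (0.51 log units; beyond the scatter), and the two steps differ by more than repeated measurements would explain: the same change on two cores in this assay, a 1.9-fold lower number (0.28 log units; within the scatter) from compound 2 to compound 3 and a 3.3-fold higher number (0.51 log units; beyond the scatter) from compound 1 to compound 4, 6.3-fold (0.80 log units) apart, beyond the scatter of two such steps

This does not show that the core alone sets the size or direction of the step, since in compound 4 the methyl sits para to a large group while in compound 3 it stands at a different place on the phenyl ring, so core and position change together in this comparison. Among these compounds, each core also offers only one such pair, and the step on the core of compound 2 lies within the scatter, so the set gives no general rule for transfer and no reason for the gap.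

The compounds shown leave open whether a methyl at the same place on the phenyl ring would give matching steps on both cores. They also leave open whether a fluorine, a chlorine or a methoxy group at that place would follow the step seen for methyl on either core.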